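The source may report more compounds than this note shows. Statements on the series, on what has been measured and on what is new or still open speak of the compounds shown alone.

Values in a functional assay on WHCO1 cells (Homo sapiens) for antiproliferative activity, read by MTT assay, with a stated time of 48 h; on this read-out higher numbers stand for weaker inhibition and lower numbers for stronger inhibition:
compound 1 `C=CCSSC=CC[S+]([O-])Cc1ccc(OC)cc1`: 7400 nM
compound 2 `COc1ccc(CSSC=CC[S+]([O-])Cc2ccc(OC)cc2)cc1`: 2100 nM
compound 3 `COc1ccc(C[S+]([O-])CC=CSSCc2ccc(F)cc2)cc1`: 16000 nM

In this assay, compound 1 has the second highest of the three numbers, lying between the other two. The next analogue, compound 4 `C=CCSSC=CC[S+]([O-])Cc1ccccc1`, has hydrogen in place of methoxy on an aromatic carbon, para to a large group: hydrogen in place of methoxy on an aromatic carbon.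

Going by the values given here, no measured pair makes this exact change. The closest is a 7.6-fold higher number from compound 2 to compound 3 (0.88 log units; beyond the scatter), a modest step that also removes a methoxy, but it puts fluoro at a different aromatic carbon and enters no hydrogen. The steps of a 3.5-fold lower number from compound 1 to compound 2 (0.55 log units; beyond the scatter) and a 2.2-fold higher number from compound 1 to compound 3 (0.33 log units; beyond the scatter) are also modest, but they replace vinyl elsewhere and bear only on the general size of steps in this small set.

A small move towards weaker inhibition is therefore expected, probably not beyond the scatter: a 1.2-fold higher number from compound 1 to compound 4 (0.09 log units; within the scatter). Compound 4 is estimated at 9000 nM, with an expected range of 3500 nM to 22000 nM.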

Compound 4, half-maximal inhibitory concentration: 8900 nM
For compound 4 the middle estimate is 1.0-fold (0.00 log units) above the measured one; the range from low to high includes it.
By their numbers in this assay, from the lowest: compound 2; then compounds 1, 4 and 3 (each within the scatter of the next, the first and the last beyond it).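

In this assay, hydrogen in place of methoxy on an aromatic carbon, para to a large group, gives a 1.2-fold higher number from compound 1 to compound 4 (0.08 log units; within the scatter) and so leaves the number within the scatter. Going by these compounds alone, this is the first reading of methoxy at this place on its own, and with vinyl present the methoxy can go without a change beyond the scatter. The earlier 7.6-fold higher number from compound 2 to compound 3 (0.88 log units; beyond the scatter) is beyond the scatter but concerns fluoro in place of methoxy at a different aromatic carbon, so it does not carry over to this position. No measurement here gives a reason for either result.

As far as these compounds go, whether an amine or a carboxylic acid at this aromatic carbon would shift the number remains open. Also open, from the compounds shown here alone, is whether hydrogen in place of methoxy here would read the same with 4-methoxyphenyl in place of vinyl, as in compound 2.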